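The compounds below may be only part of what the source reports. "The series", "measured", "known", "first", "only" and "open" are said of these compounds alone.

Working notes on the series. For the measured compounds named here, in an ADME assay on NSO cells (Mus musculus) for cytotoxicity, read by MTT assay (on this read-out higher numbers stand for lower toxicity in this test and lower numbers for higher toxicity in this test), compound 1 `Clc1ccc(C(Nc2ccnc3cc(Cl)ccc23)c2ccc(CN3CCCC3)cc2)cc1` gives 8.6 uM and compound 2 `FC(F)(F)c1ccc2c(NC(c3ccc(Cl)cc3)c3ccc(CN4CCCC4)cc3)ccnc2c1` gives 12.1 uM, so compound 1 cannot be separated from its only measured neighbour. Compound 3 `Clc1cccc(C(Nc2ccnc3cc(Cl)ccc23)c2ccc(CN3CCCC3)cc2)c1` carries this change: 3-chlorophenyl in place of 4-chlorophenyl on a saturated chain carbon bound to an aromatic carbon and a nitrogen on an aromatic ring. Going by the values given here, the single measured step, a 1.4-fold higher number from compound 1 to compound 2 (0.15 log units; within the scatter), leaves the 4-chlorophenyl untouched, so it is only a weak guide, and no measured step covers the move to 3-chlorophenyl. No shift beyond the scatter is expected, and the estimated step is a 1.0-fold higher number from compound 1 to compound 3 (0.02 log units; within the scatter). Compound 3 is expected at 9 uM, within a range of 4.5 uM to 18 uM.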

Compound 3, half-maximal toxic concentration: 23.8 uM
Beside the measured number, compound 3's estimate is 2.6-fold (0.42 log units) below it; the measured number lies above the stated range.
By their numbers in this assay, from the lowest: compounds 1, 2 and 3 (each within the scatter of the next, the first and the last beyond it).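

In this assay, for the compounds shown here, the swap on the saturated chain carbon gives a 2.8-fold higher number from compound 1 to compound 3 (0.44 log units; beyond the scatter) and is the first step beyond the scatter: the 3-chlorophenyl and 4-chlorophenyl groups are not interchangeable here, though the two compounds have the same atoms. The higher number stands for lower toxicity in this test, a modest gain. Nothing at hand accounts for this step. Open, as far as these compounds go, is whether plain phenyl or a methoxy or trifluoromethyl group on that phenyl would follow the same direction. Also open, from the compounds shown here alone, is whether the step holds with trifluoromethyl on the core of compound 2.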